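Trimming a morpholine to methyl on the shared core

This account rests on a few compounds, and the source may have more. Where it says the series, first, only, none or still open, it means among the compounds named here.

Measured so far:
compound 1 `O=C(Nc1cnc(-n2nccn2)c(Cl)c1)Nc1cnc2cc(Cl)nn2c1C1CC1`: < 25 mL.min-1.g-1
compound 2 `CO[C@@H](C)c1c(NC(=O)Nc2cnc(-n3nccn3)c(Cl)c2)cnc2cc(Cl)nn12`: < 25 mL.min-1.g-1
compound 3 `C[C@H]1COC[C@H](C)N1c1c(NC(=O)Nc2ccnc(C(F)(F)F)c2)cnc2cc(Cl)nn12`: 114 mL.min-1.g-1

In an ADME assay on microsomes from liver (Homo sapiens) for metabolic stability (on this read-out lower numbers stand for slow clearance and higher numbers for fast clearance), compound 1 gives < 25 mL.min-1.g-1, which is a limit of the assay rather than a number. Compound 2 likewise sits at < 25 mL.min-1.g-1, again a limit. The step that the two limits leave unreadable from compound 1 to compound 2 therefore cannot be read. Going by the values given here, compound 3 stands apart: in this assay compound 3 gives 114 mL.min-1.g-1, the only number among the three.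

Compound 4 `Cc1c(NC(=O)Nc2ccnc(C(F)(F)F)c2)cnc2cc(Cl)nn12` is not yet measured. It differs from compound 3 by methyl in place of 3,5-dimethylmorpholin-4-yl on an aromatic carbon. Among the compounds with values here, no measured step mirrors this change, but the limit of < 25 mL.min-1.g-1 in this assay, at which 2 of the 3 values shown sit, shows where compounds carrying small groups on the shared core sit, so a drop in this assay is expected, by a 3.8-fold lower number from compound 3 to compound 4 (0.58 log units; beyond the scatter). Compound 4 is thus estimated at 30 mL.min-1.g-1, ranging from 10 mL.min-1.g-1 to 90 mL.min-1.g-1.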

Compound 4, intrinsic clearance in microsomes: < 25 mL.min-1.g-1
Compound 4 ended at the assay's limit; the forecaster's own chance of this, stated with the estimate: 45%; middle value at least 1.2-fold (0.07 log units) away from the limit.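

In this assay, going by these compounds alone, methyl in place of 3,5-dimethylmorpholin-4-yl on this aromatic carbon gives an at least 4.5-fold lower number from compound 3 to compound 4 (0.65 log units; beyond the scatter), the first readable step at this position, while the earlier step between compound 1 and compound 2 cannot be read. The true size of this step stays hidden, as compound 4 sits at a limit of the assay. Only compound 3 now stands clear of that limit: the limit of < 25 mL.min-1.g-1 in this assay, at which 3 of the 4 values shown sit.

The compounds shown leave open how far clearance climbs with other groups at this position, such as a dimethylamino group or an unsubstituted morpholine. Any order among the compounds at the limit also remains unknown.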